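Formyl in place of chloro on compound 2

The source may hold more compounds than are shown below. What is called first, only, known or untested is meant among the compounds shown, and "the series" means these compounds.

Measured so far:
compound 1 `C/C(=N\OCC(=O)N[C@H](C(=O)N[C@@H](CCCCN)C(=O)N1CCC[C@H]1C(=O)N[C@@H](CCCCN)C(=O)NCC(N)=O)[C@@H](C)O)c1ccc(NC(=O)c2cc(Br)ccc2O)cc1` with > 200000 nM (a limit)
compound 2 `O=C(Nc1ccc(C(F)(F)F)cc1)c1cc(Cl)ccc1O` with 5800 nM

Within the data shown here, in a functional assay on HepG2 cells (Homo sapiens) for cytotoxicity, read by MTT assay, with a stated time of 24 h (a lower number here means a stronger inhibitor, a higher number a weaker inhibitor), compound 2 gives 5800 nM and this is the only actual number so far. For compound 1 the reading (> 200000 nM) is a limit of the assay and not a number.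

The next compound to be tested is compound 3 `O=Cc1ccc(O)c(C(=O)Nc2ccc(C(F)(F)F)cc2)c1`, which carries formyl in place of chloro on an aromatic carbon, para to a hydroxy group (formyl in place of chloro on an aromatic carbon). Among the measured compounds shown here, no measured step is available to size this change, so the expectation is a loose one. A moderate weakening is expected in this assay and the estimated step is a 2.6-fold higher number from compound 2 to compound 3 (0.41 log units; beyond the scatter) (a higher number). Compound 3 is estimated at 15000 nM with an expected range of 5000 nM to 60000 nM in this assay once it is measured.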

Compound 3, half-maximal inhibitory concentration: 17600 nM
The estimate for compound 3 lay 1.2-fold (0.07 log units) below the measured number; measured number inside the range.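

In this assay, the aromatic carbon para to a hydroxy group proves sensitive to what it carries: with the rest of the molecule unchanged, formyl in place of chloro gives a 3.0-fold higher number from compound 2 to compound 3 (0.48 log units; beyond the scatter). This is the first measured step among the compounds shown, and it puts chloro ahead of formyl at this position, though it rests on this single pair. Compound 1 is the only one that stands at a limit and not at a number: the limit of > 200000 nM in this assay, at which 1 of the 3 values shown sits.

The compounds shown leave open whether other groups at this aromatic carbon, such as a nitrile, an amine or a carboxylic acid, would fall nearer to chloro or to formyl. They also leave open whether replacing the trifluoromethyl group would shift the number in this assay.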